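Diaryl urea series: removing one trifluoromethyl group

The compounds below may be only part of what the source reports. "The series", "measured", "known", "first", "only" and "open" are said of these compounds alone.

Compound 1 `O=C(Nc1cccc(-n2cc(-c3ccncc3)c(-c3cc(O)cc(Cl)c3)n2)c1)Nc1ccc(Cl)c(Cl)c1` and compound 2 `COc1cc(Cl)cc(-c2nn(-c3cccc(NC(=O)Nc4cc(C(F)(F)F)cc(C(F)(F)F)c4)c3)cc2-c2ccncc2)c1` share a common core. In a functional assay on SW-620 cells (Homo sapiens) for inhibition, read by sulforhodamine B assay, with a stated time of 48 h, tested at 1 uM (on this read-out higher numbers stand for a weaker effect at the one concentration tested and lower numbers for a stronger effect), compound 1 gives 102%, while compound 2 gives 19%, the lowest of the two numbers, with compound 1 standing higher by a gap beyond the scatter. Compound 3 `COc1cc(Cl)cc(-c2nn(-c3cccc(NC(=O)Nc4cccc(C(F)(F)F)c4)c3)cc2-c2ccncc2)c1` differs from compound 2 by hydrogen in place of trifluoromethyl on an aromatic carbon. Among the measured compounds shown here, no step between measured compounds is available to anchor this change, so the expectation is an upward step of moderate size, a number 26 percentage points higher from compound 2 to compound 3 (beyond the scatter), beyond the scatter. Compound 3 is estimated at 45%, with a range from 20% to 80%.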

Compound 3, a percentage reported as activity, at one concentration (the size of the read-out at that concentration, not a potency): 74%
For compound 3 the middle estimate is 29 percentage points below the measured one; the measured number falls inside the stated range.
By their numbers in this assay, from the lowest: compound 2; then compound 3; then compound 1.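

In this assay, among the compounds shown here, the first one-place step is a number 55 percentage points higher from compound 2 to compound 3 (beyond the scatter) for hydrogen in place of trifluoromethyl on an aromatic carbon. The effect at the one concentration tested therefore depends heavily on this single group, and the trifluoromethyl group remaining in compound 3 does not hold the level of compound 2. No measured data explain this step.

From the compounds shown here alone, whether a chlorine, a methyl group or a nitrile at this position would keep the effect remains open. Going by these compounds, whether the step holds with the hydroxyl group of compound 1 in place of methoxy also remains open.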